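A smaller saturated ring at the amide terminus of compound 1

A few compounds are considered here, and "the series" means these few. Any claim that something is new, unique, unknown or untested is made for them only; others in the source may bear on it.

Compound 1 `CS(=O)(=O)c1ccc(C(=O)NCCCC(=O)N2Cc3ccccc3C2)cc1[N+](=O)[O-]` was examined in an ADME assay on HepG2 cells (Homo sapiens) for cytotoxicity, read by CellTiter-Glo and ATP content, with a stated time of 72 h; a higher number here means that more compound is needed for the effect, a lower number that less compound is needed. In this assay compound 1 gives > 27000 nM, a limit of the assay and not a number. Compound 2 `Cc1ccc(N2CCN(C(=O)CCCNC(=O)c3ccc(S(C)(=O)=O)c([N+](=O)[O-])c3)CC2)cc1` stands at the same point: in this assay compound 2 gives > 27000 nM, again a limit. For the measured compounds named here, compound 3 `CN(CC(=O)N1CCN(c2ccc(C(F)(F)F)cc2)CC1)C(=O)c1ccc(S(C)(=O)=O)c([N+](=O)[O-])c1` is the only one with a numeric reading, giving 11900 nM in this assay. Going by the values given here, compound 1 thus sits at the limit of > 27000 nM in this assay, at which 2 of the 3 values shown sit, together with compound 2, with compound 3 the single measured value.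

Compound 4 `CC1CCN(C(=O)CCCNC(=O)c2ccc(S(C)(=O)=O)c([N+](=O)[O-])c2)CC1` differs from compound 1 in one place, on a carbonyl carbon whose other neighbours are a saturated chain carbon a group of 7 heavy atoms (6 carbon, 1 nitrogen; one six-membered non-aromatic ring with 1 hetero atom) in place of a group of 9 heavy atoms (8 carbon, 1 nitrogen; one five-membered non-aromatic ring with 1 hetero atom, one six-membered aromatic ring of carbon only), on a carbonyl carbon: the 4-methylpiperidin-1-yl group with one six-membered non-aromatic ring enters where a group with a five-membered non-aromatic ring and a six-membered aromatic ring of carbon only leaves.

Among the compounds with values here, no measured pair shows how far such an exchange moves the reading. The step from compound 1 to compound 4 is expected to stay within the scatter, a step that the limit leaves unreadable from compound 1 to compound 4. Compound 4 is therefore expected to give about 30000 nM in this assay, between 14000 nM and 65000 nM, and is likely to be reported once more as a limit.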

Compound 4, half-maximal effective concentration: > 27000 nM
Compound 4: a limit, no number; the forecaster's own chance of this, stated with the estimate: 70%; the middle value is on the limit's open side.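

For the compounds shown here, compound 1 and compound 4 both stand at a limit in this assay, not at a number, so no step between them can be read. The compounds shown leave open how far the 4-methylpiperidin-1-yl group moves the reading, for most of them share one point: the limit of > 27000 nM in this assay, at which 3 of the 4 values shown sit.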